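Changing the Aryl Group on the Sulfonyl Sulfur

The source may report more compounds than this note shows. Statements on the series, on what has been measured and on what is new or still open speak of the compounds shown alone.

Measured compounds:
compound 1, `COc1ccc(S(=O)(=O)c2cnc3ccc(OC)cc3c2N2CCC(C)CC2)cc1`: 41%
compound 2, `COc1ccc2ncc(S(=O)(=O)c3ccc(F)cc3)c(N3CCC(C)CC3)c2c1`: 27%

In an assay on isolated protein for displacement of a labelled ligand from metabotropic glutamate receptor 5 (Homo sapiens), with a stated time of 60 min, tested at 1 uM (on this read-out higher numbers stand for more inhibition at the one concentration tested (going by the name of the read-out) and lower numbers for less inhibition), compound 1 gives 41%, while compound 2 gives 27%. Among the measured compounds shown here, compound 2 therefore stands lowest of the two numbers, and the single measured step, a number 14 percentage points lower from compound 1 to compound 2 (beyond the scatter), came with fluoro in place of methoxy on an aromatic carbon.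

Compound 3, `COc1ccc2ncc(S(=O)(=O)c3ccc(C)c(F)c3)c(N3CCC(C)CC3)c2c1`, has not yet been measured. It differs from compound 2 by 3-fluoro-4-methylphenyl in place of 4-fluorophenyl on a sulfonyl sulfur. For the measured compounds named here, no measured step touches this part of the molecule in the same way: the only step available moved from methoxy to fluoro on that ring, and it was modest. Adding a methyl group to the fluorophenyl while moving the fluorine has no direct precedent here, so the expectation rests on the modest size of the one known step.

Compound 3 is expected to give 30%, within a range from 10% to 50%. The step of a number 3 percentage points higher from compound 2 to compound 3 (within the scatter) is accordingly expected to stay within the scatter.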

Compound 3, a percentage reported as inhibition, at one concentration (the size of the read-out at that concentration, not a potency): 73%
The estimate for compound 3 lay 43 percentage points below the measured number; measured number outside the range, above it.
By their numbers in this assay, from the lowest: compound 2; then compound 1; then compound 3.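

In this assay, the aryl group on the sulfonyl sulfur can shift the reading far more than the earlier fluoro-for-methoxy change suggested: 3-fluoro-4-methylphenyl in place of 4-fluorophenyl gave a number 46 percentage points higher from compound 2 to compound 3 (beyond the scatter), a large step from a small change in the group's size. The same group in place of 4-methoxyphenyl gave a number 32 percentage points higher from compound 1 to compound 3 (beyond the scatter), so the gain holds against both earlier aryl groups and places compound 3 highest of the three in this set. Nothing available here explains why this exchange raises the reading.

As far as these compounds go, whether the rise follows the added methyl group, the changed place of the fluorine or the two together stays open: a plain 4-methylphenyl and a plain 3-fluorophenyl on the sulfonyl sulfur would be needed to tell these apart. Also open, from the compounds shown here alone, is how the reading responds when an ethyl group, a trifluoromethyl group or an amine takes the place of that methyl, and what potency lies behind a percentage taken at a single concentration.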